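The source may report more compounds than this note shows. Statements on the series, on what has been measured and on what is new or still open speak of the compounds shown alone.

Measured compounds:
compound 1, `COc1cccc(-c2ccc([C@H]3S[C@@H](C)C(=O)Nc4c3c(C)nn4-c3ccccc3C)cc2)c1`, 1800 nM
compound 2, `Cc1nn(-c2ccccc2Cl)c2c1C(c1ccc(Oc3ccccc3)cc1)SC(C)C(=O)N2`, 2700 nM
compound 3, `Cc1cccc(-n2nc(C)c3c2NC(=O)[C@H](C)S[C@@H]3c2ccc(Oc3ccccc3)cc2)c1`, 2400 nM

All three were tested in an assay on isolated protein for agonist activity at Bile acid receptor (Homo sapiens), read by AlphaScreen, with a stated time of 30 min; a higher number here means that more compound is needed for the effect, a lower number that less compound is needed. Compound 1 gives 1800 nM, the lowest of the three numbers, yet its gap to compound 3 at 2400 nM and its gap to compound 2 at 2700 nM both fall within the usual scatter of repeated measurements, so the three compounds cannot be told apart on these numbers. Going by the values given here, no two of the measured compounds differ in just one place, so no single step is available to calibrate how a change in one group moves the number.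

Compound 4, `Cc1ccccc1-n1nc(C)c2c1NC(=O)[C@H](C)S[C@@H]2c1ccc(-c2ccccc2)cc1`, has not been measured. It differs from compound 1 in one place: hydrogen in place of methoxy on an aromatic carbon. Methoxy leaves and hydrogen enters on an aromatic carbon of a six-membered aromatic ring of carbon only, meta to a large group; cut one bond further out, 3-methoxyphenyl becomes phenyl. No shown step tells how this assay responds to such a change. The expectation is a step of a 1.4-fold higher number from compound 1 to compound 4 (0.14 log units; within the scatter), staying within the scatter, with no clear direction. Compound 4 is expected to give 2500 nM, with a range from 1000 nM to 6500 nM.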

Compound 4, half-maximal effective concentration: 990 nM
For compound 4 the middle estimate is 2.5-fold (0.40 log units) above the measured one; measured number below the stated range.
By their numbers in this assay, from the lowest: compounds 4, 1, 3 and 2 (each within the scatter of the next, the first and the last beyond it).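

Removing the methoxy group from an aromatic carbon, so that 3-methoxyphenyl becomes phenyl, gives a 1.8-fold lower number from compound 1 to compound 4 (0.26 log units; within the scatter) in this assay. Going by these compounds alone, this is the first single-place comparison, and it shows that the methoxy group is not needed for the compound to keep a number of this size, since the plain phenyl group cannot be told apart from it here. Nothing shown explains this outcome.

The compounds shown leave open whether any other group at this carbon, such as an amine, a carboxylic acid or a longer chain like ethoxy, would move the number beyond the scatter. They also leave open whether a methoxy group elsewhere on the same ring would behave in the same way.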